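A few compounds are considered here, and "the series" means these few. Any claim that something is new, unique, unknown or untested is made for them only; others in the source may bear on it.

Compounds measured so far:
- Compound 1, `Cn1cc(C2=C(c3cccc4ccc(CN)cc34)C(=O)NC2=O)c2ccccc21`: > 316 nM
- Compound 2, `CNCc1ccc2ccc(Cl)c(C3=C(c4cn(C)c5ccccc45)C(=O)NC3=O)c2c1`: 21 nM

In an assay on isolated protein for inhibition of protein kinase C theta type (Homo sapiens), read by scintillation proximity assay and 33P incorporation, with a stated time of 60 min, in the presence of a further agent that is not named here (on this read-out higher numbers stand for weaker inhibition and lower numbers for stronger inhibition), compound 1 gives > 316 nM; this is a limit of the assay and not a number, and it is the only limit among the two values shown (the limit of > 316 nM in this assay, at which 1 of the 2 values shown sits). In this assay, among the compounds with values here, compound 2 gives 21 nM, the only actual number in the set, so there is no measured pair that would show how a change of structure moves the read-out.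

The next compound, compound 3, `COCCNCc1ccc2ccc(Cl)c(C3=C(c4cn(C)c5ccccc45)C(=O)NC3=O)c2c1`, differs from compound 2 in one place: methoxymethyl in place of hydrogen on a saturated chain carbon bound to an amine nitrogen. Within the data shown here, no step between measured compounds is known here, so the expectation rests only on the size of this change, which adds a short chain without a ring or charge. The step from compound 2 to compound 3 is expected to be small, a 1.4-fold higher number from compound 2 to compound 3 (0.15 log units; within the scatter), and most likely not beyond the usual scatter. Compound 3 is therefore estimated at 30 nM, with a range from 10 nM to 100 nM.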

Compound 3, half-maximal inhibitory concentration: 21 nM
For compound 3 the middle estimate is 1.4-fold (0.15 log units) above the measured one; low and high end bracket the measured number.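

Within the data shown here, the first measured pair in the set concerns the group on the amine nitrogen: going from methyl to 2-methoxyethyl, this assay shows no change at the digits printed from compound 2 to compound 3 (within the scatter). Among these compounds, this is the first direct evidence about this position, and it shows that methoxymethyl, with its 3 heavy atoms and 1 hydrogen-bond acceptor, can stand in place of hydrogen on this saturated chain carbon without a change in the read-out that exceeds the usual scatter. Among the compounds shown here, the values shown give no reason for this outcome, so the pair records only that the number stayed put, not why.

On these data alone, one pair cannot show how far this tolerance extends, so it remains open whether a longer chain, a carboxylic acid or a morpholine ring at the same place would leave the read-out equally unmoved. Compound 1 differs from compound 2 in more than one place, so the compounds shown also leave open how much the chlorine and the methyl on the amine nitrogen each contribute on their own.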